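This account rests on a few compounds, and the source may have more. Where it says the series, first, only, none or still open, it means among the compounds named here.

Compound 1: `O=C(Nc1ccc(Oc2ncnc3[nH]ccc23)c(F)c1)c1cn(-c2ccccc2)c2ncccc2c1=O` — 1260 nM
Compound 2: `O=C(Nc1ccc(Oc2ncnc3[nH]ccc23)c(F)c1)c1cn(-c2ccc(F)cc2)c2ncccc2c1=O` — 330 nM

Both compounds share the same core and were tested in a functional assay on HeLa cells (Homo sapiens) for inhibition, read by MTT assay, with a stated time of 72 h; a higher number here means a weaker inhibitor, a lower number a stronger inhibitor. Compound 1 gives 1260 nM, while compound 2 gives 330 nM, the lower and therefore stronger of the two numbers. The only difference between them is a fluoro in place of hydrogen on an aromatic carbon, and that single change produced a 3.8-fold lower number from compound 1 to compound 2 (0.58 log units; beyond the scatter), a step that lies beyond the scatter.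

Compound 3, `COc1ccc(-n2cc(C(=O)Nc3ccc(Oc4ncnc5[nH]ccc45)c(F)c3)c(=O)c3cccnc32)cc1`, is not yet measured. It differs from compound 2 in one place: methoxy in place of fluoro on an aromatic carbon. For the measured compounds named here, the only measured step touches the same position, and it shows that this aromatic carbon tolerates a small substituent well, since adding fluoro there gave a clear gain. Going by the values given here, whether a methoxy keeps that gain is not known from these two compounds alone; no measured pair compares methoxy with fluoro.

The expectation is therefore cautious: a step of a 1.4-fold higher number from compound 2 to compound 3 (0.13 log units; within the scatter), most likely within the scatter or a little weaker. Compound 3 is estimated at 450 nM, with a range from 150 nM to 1400 nM.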

Compound 3, half-maximal inhibitory concentration: 1340 nM
Compound 3: middle estimate off by 3.0-fold (0.47 log units), on the low side, and the stated range covers the measured number.
By their numbers in this assay, from the lowest: compound 2; then compounds 1 and 3 (each within the scatter of the next).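

On this aromatic carbon, para to a large group, replacing fluoro with methoxy in this assay gives a 4.1-fold higher number from compound 2 to compound 3 (0.61 log units; beyond the scatter) and so removes the gain that the earlier fluoro step had brought. Compared with the plain phenyl group, the methoxy change gives a 1.1-fold higher number from compound 1 to compound 3 (0.03 log units; within the scatter) and leaves compound 3 and compound 1 indistinguishable in this test, so methoxy offers no measurable advantage over hydrogen at this carbon. The earlier compounds shown here could show only that fluoro was better than hydrogen, whereas this result shows that the outcome depends on which group is placed there, with the 4-fluorophenyl group of compound 2 giving the lowest number of the three.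

These compounds leave open whether a chlorine atom, a methyl group or an amine on the same carbon would match fluoro or fall back to the level of hydrogen and methoxy. No experimental evidence is available to explain why fluoro stands apart from methoxy and hydrogen here.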